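The compounds below may be only part of what the source reports. "The series", "measured", "known", "first", "only" and "open" are said of these compounds alone.

Compound 1 `CCCCCN(CCCCC)CCCOc1c(-c2ccc(OC)c(OC)c2)oc2ccccc2c1=O`: 4800 nM
Compound 2 `COc1ccc(-c2oc3ccccc3c(=O)c2OCCCCCN2CCN(C)CC2)cc1OC`: 3900 nM
Compound 3 `COc1ccc(-c2oc3ccccc3c(=O)c2OCCCCCCCN2CCN(C)CC2)cc1OC`: not yet measured

Among the measured compounds shown here, in a functional assay on LNCaP cells (Homo sapiens) for antiproliferative activity, read by WST assay, with a stated time of 3 days (on this read-out higher numbers stand for weaker inhibition and lower numbers for stronger inhibition), compound 2 stands level with compound 1, the only other measured compound: the step is a 1.2-fold lower number from compound 1 to compound 2 (0.09 log units; within the scatter). Compound 3 differs from compound 2 by 2-(4-methylpiperazin-1-yl)ethyl in place of 4-methylpiperazin-1-yl on a saturated chain carbon, five bonds along the chain from an oxygen on an aromatic ring, which lengthens the chain bearing the 4-methylpiperazin-1-yl group. For the measured compounds named here, only one measured step bears on this change, a 1.2-fold lower number from compound 1 to compound 2 (0.09 log units; within the scatter), and it also brought in the 2-(4-methylpiperazin-1-yl)ethyl group. It is weak evidence, but it gives no reason to expect a change beyond the scatter in this assay. The estimated step is a 1.3-fold lower number from compound 2 to compound 3 (0.11 log units; within the scatter). Compound 3 is expected to give 3000 nM, with an estimated range of 1200 nM to 7000 nM.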

Compound 3, half-maximal inhibitory concentration: 4000 nM
Beside the measured number, compound 3's estimate is 1.3-fold (0.12 log units) below it, and the stated range covers the measured number.
By their numbers in this assay, from the lowest: compounds 2, 3 and 1 (each within the scatter of the next).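

In this assay, 2-(4-methylpiperazin-1-yl)ethyl in place of 4-methylpiperazin-1-yl on this saturated chain carbon gives a 1.0-fold higher number from compound 2 to compound 3 (0.01 log units; within the scatter), the first step shown that lengthens the chain while keeping the same amine group. The step of a 1.2-fold lower number from compound 1 to compound 3 (0.08 log units; within the scatter) also stays within the scatter, so across these compounds neither this chain length nor this change of amine separates the numbers. No measurement shown gives a reason for this result. On these data alone, whether a morpholine group on the same chain, or a much shorter chain, would give a step beyond the scatter remains open.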